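Moving a Hydroxyl Group: Two Pairs, One Change

A few compounds are considered here, and "the series" means these few. Any claim that something is new, unique, unknown or untested is made for them only; others in the source may bear on it.

Measured compounds:
compound 1 `Oc1cccc(-c2cc(-c3ccc(F)cc3)cc(-c3ccccc3O)n2)c1`: > 50000 nM
compound 2 `Oc1ccc(-c2cc(-c3ccc(F)cc3)cc(-c3ccccc3O)n2)cc1`: > 50000 nM
compound 3 `Oc1cccc(-c2cc(-c3ccccc3F)cc(-c3cccc(O)c3)n2)c1`: 5300 nM

In a functional assay on HCT-15 cells (Homo sapiens) for inhibition (on this read-out lower numbers stand for stronger inhibition and higher numbers for weaker inhibition), compound 1 reaches only a limit, > 50000 nM, not a number. Compound 2 likewise gives only a limit, > 50000 nM. Compound 3 gives 5300 nM. Compound 1 and compound 2 differ by 4-hydroxyphenyl in place of 3-hydroxyphenyl on an aromatic carbon, and because both sit at the limit of > 50000 nM in this assay, at which 2 of the 3 values shown sit, the step that the two limits leave unreadable from compound 1 to compound 2 cannot be read. Compound 4 `Oc1ccc(-c2cc(-c3ccccc3F)cc(-c3cccc(O)c3)n2)cc1` is not yet measured; it differs from compound 3 by 4-hydroxyphenyl in place of 3-hydroxyphenyl on an aromatic carbon. This is the same kind of change as in the first pair, but the surroundings differ: there the place is meta to a 2-hydroxyphenyl group and a 4-fluorophenyl group, here it is meta to a 2-fluorophenyl group and a 3-hydroxyphenyl group. The difference between the two cores is not broken down here. The earlier step has no readable size, so the expected step of a 1.7-fold higher number from compound 3 to compound 4 (0.23 log units; within the scatter) in this assay rests only on compound 3 giving 5300 nM and is uncertain. Compound 4 is expected to give about 9000 nM, between 2000 nM and 50000 nM.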

Compound 4, half-maximal inhibitory concentration: 5630 nM
Estimate against measurement, compound 4: 1.6-fold (0.20 log units) above; measured number inside the range.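

In this assay, putting 4-hydroxyphenyl in place of 3-hydroxyphenyl on the core of compound 3 gives a 1.1-fold higher number from compound 3 to compound 4 (0.03 log units; within the scatter), so on this core the two placements of the hydroxyl cannot be told apart. Whether the change acts the same way on the other core is not shown, since this one readable step has nothing to be set against. Compound 1 and compound 2 give only limits, and the step between them cannot be read because neither limit is a number: the limit of > 50000 nM in this assay, at which 2 of the 4 values shown sit.

On these data alone, compound 3 and compound 1 differ in more than one place, so what the 2-fluorophenyl, 4-fluorophenyl and 2-hydroxyphenyl groups each contribute stays open. Also open, as far as these compounds go, is how an amine or a carboxylic acid in place of the hydroxyl would read in this assay.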